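The source may report more compounds than this note shows. Statements on the series, on what has been measured and on what is new or still open speak of the compounds shown alone.

Among the compounds with values here, in a toxicity assay on MT4 cells (Homo sapiens) for cytotoxicity, read by MTT assay, with a stated time of 5 days (on this read-out lower numbers stand for higher toxicity in this test and higher numbers for lower toxicity in this test), compound 1 (`Cc1cc(-c2ccco2)cc(C)c1Nc1ccnc(Nc2ccc(C#N)cc2)n1`) gives 1700 nM and compound 2 (`Cc1cc(-c2ccnc(C(F)(F)F)c2)cc(C)c1Nc1ccnc(Nc2ccc(C#N)cc2)n1`) gives 6100 nM, the higher of the two numbers so far. Compound 3 (`Cc1cc(-c2cnc(C#N)nc2)cc(C)c1Nc1ccnc(Nc2ccc(C#N)cc2)n1`) changes one group of compound 2: 2-cyanopyrimidin-5-yl in place of 2-(trifluoromethyl)pyridin-4-yl on an aromatic carbon. It carries 2-cyanopyrimidin-5-yl in place of 2-(trifluoromethyl)pyridin-4-yl, on the same aromatic carbon. Within the data shown here, only one measured step swaps a group at this place, a 3.6-fold higher number from compound 1 to compound 2 (0.55 log units; beyond the scatter), and it is modest. With so little to go on, no step beyond the scatter is expected in this assay, perhaps a slightly lower number. The estimated step is a 1.5-fold lower number from compound 2 to compound 3 (0.18 log units; within the scatter). The expected value for compound 3 is 4000 nM, within a range of 1500 nM to 11000 nM.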

Compound 3, half-maximal cytotoxic concentration: 3100 nM
For compound 3 the middle estimate is 1.3-fold (0.11 log units) above the measured one; low and high end bracket the measured number.
By their numbers in this assay, from the lowest: compounds 1, 3 and 2 (each within the scatter of the next, the first and the last beyond it).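

In this assay, 2-cyanopyrimidin-5-yl at this position gives a 2.0-fold lower number from compound 2 to compound 3 (0.29 log units; within the scatter) and a 1.8-fold higher number from compound 1 to compound 3 (0.26 log units; within the scatter). Compound 3 therefore cannot be ordered against either compound 1 or compound 2, although those two differ beyond the scatter. No measurement here accounts for these numbers. As far as these compounds go, all three groups at this place are aromatic rings, so it remains open how a non-ring group, such as an amine, a carboxylic acid or a longer chain, would read in this test.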